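Ethyl Ester on the Adenine Hydroxypropanoate Core: Expected Cytotoxicity

This account rests on a few compounds, and the source may have more. Where it says the series, first, only, none or still open, it means among the compounds named here.

Compound 2 `CC(C)(C)OC(=O)C(O)Cn1cnc2c(N)ncnc21` carries a tert-butyl ester on the shared core. In a functional assay on Vero cells (Chlorocebus sabaeus) for cytotoxicity (on this read-out higher numbers stand for lower toxicity in this test and lower numbers for higher toxicity in this test), compound 2 reaches only the limit of the assay, > 400 ug/mL. Compound 1 `CC(C)OC(=O)C(O)Cn1cnc2c(N)ncnc21` likewise stops at the limit, > 400 ug/mL. The step that the two limits leave unreadable from compound 1 to compound 2 therefore gives no size, since both measurements sit at the limit of > 400 ug/mL in this assay, at which 2 of the 2 values shown sit. Compound 3 `CCOC(=O)C(O)Cn1cnc2c(N)ncnc21` differs from compound 2 by ethyl in place of tert-butyl on an oxygen next to a carbonyl group. Within the data shown here, no measured step offers a readable size, so no shift beyond the scatter is expected. Compound 3 is estimated at 400 ug/mL, between 200 ug/mL and 800 ug/mL, which means an expected step of a number no higher from compound 2 to compound 3 (the limit leaves the size open).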

Compound 3, minimum cytotoxic concentration: > 400 ug/mL
Compound 3 ended at the assay's limit; the forecaster's own chance of this, stated with the estimate: 85%; the middle value lies on the limit itself.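

Among these compounds, no step among compound 1, compound 2 and compound 3 can be read in this assay, since all three stop at a limit: the limit of > 400 ug/mL in this assay, at which 3 of the 3 values shown sit. The compounds shown leave open whether changing the ester group alters cytotoxicity at all.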